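The source may hold more compounds than are shown below. What is called first, only, known or untested is meant among the compounds shown, and "the series" means these compounds.

Among the compounds with values here, in a functional assay on HT-29 cells (Homo sapiens) for antiproliferative activity, read by sulforhodamine B assay, with a stated time of 48 h (on this read-out lower numbers stand for stronger inhibition and higher numbers for weaker inhibition), compound 2 `CCc1ccc(NS(=O)(=O)c2ccc(N3CCNC3=O)cc2)cc1` gives 660 nM, the only true number among the values so far. Compound 1 `O=C1NCCN1c1ccc(S(=O)(=O)Nc2ccc(C3CCCCC3)cc2)cc1` reads > 1000 nM, which is a limit of the assay. Compound 3 `CCCCCCCc1ccc(NS(=O)(=O)c2ccc(N3CCNC3=O)cc2)cc1` reads > 1000 nM, which is also a limit.

The next compound, compound 4 `Cc1cccc(NS(=O)(=O)c2ccc(N3CCNC3=O)cc2)c1C`, carries 2,3-dimethylphenyl in place of 4-ethylphenyl on a sulfonamide nitrogen. Two measured steps change the same substituent group. Exchanging cyclohexyl for ethyl gave an at least 1.5-fold lower number from compound 1 to compound 2 (0.18 log units; that floor lies within the scatter), and extending the ethyl to heptyl gave an at least 1.5-fold higher number from compound 2 to compound 3 (0.18 log units; that floor lies within the scatter). Both steps are bounded only by the limit of > 1000 nM in this assay, at which 2 of the 3 values shown sit, so neither has a readable full size, and neither rearranges the carbons as compound 4 does.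

With so little to go on, no clear step beyond the scatter is expected in this assay, though a reading at the limit remains possible. The expected change is a 1.2-fold higher number from compound 2 to compound 4 (0.08 log units; within the scatter). The value for compound 4 is estimated at 800 nM, with an expected range from 300 nM to 2500 nM.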

Compound 4, half-maximal inhibitory concentration: 190 nM
For compound 4 the middle estimate is 4.2-fold (0.62 log units) above the measured one; the whole stated range lies above it.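

In this assay, within the data shown here, the change on the sulfonamide nitrogen gives a 3.5-fold lower number from compound 2 to compound 4 (0.54 log units; beyond the scatter), the first step here with a readable full size and the first beyond the scatter. Among these compounds, the two groups have the same count of heavy atoms, all carbon, and one six-membered aromatic ring each, so at this position a different arrangement of the same carbons is enough to separate compound 2 from compound 4, where the earlier steps changed the carbon count. Those earlier steps show only a floor or cannot be read at all: the limit of > 1000 nM in this assay, at which 2 of the 4 values shown sit.

Going by these compounds, it remains open whether both methyl groups of the 2,3-dimethylphenyl are needed for this lower number or one alone would give it. Also open, on these data alone, is how a phenyl ring carrying methoxy or chlorine instead would read.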